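Chain-end change in the amide series

A few compounds are considered here, and "the series" means these few. Any claim that something is new, unique, unknown or untested is made for them only; others in the source may bear on it.

Measured so far:
compound 1, `CCCCCCCCCCCCCCCC(=O)Nc1cccc2c1OC(C)(C)C2`, gives 890 nM in an assay for inhibition of acyl-CoA:cholesterol acyltransferase (Oryctolagus cuniculus), using microsomes; on this read-out higher numbers stand for weaker inhibition and lower numbers for stronger inhibition
compound 2, `CCCCCCCCCCCCC(C)(C)C(=O)Nc1c(C)cc(C)c2c1OC(C)(C)C2`, gives 33 nM in this assay
compound 3, `Cc1cc(C)c(NC(=O)C(C)(C)CCCCCCc2ccccc2)c2c1CC(C)(C)O2`, gives 81 nM in this assay

Compound 3 stands second highest of the three numbers. Its nearest neighbour is compound 2, which gives 33 nM; the step of a 2.5-fold higher number from compound 2 to compound 3 (0.39 log units; beyond the scatter) is modest but beyond the scatter. Among the compounds with values here, the furthest is compound 1, which gives 890 nM; no single-place step connects compound 1 to compound 3, so the two values are only set side by side.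

Compound 4, `Cc1cc(C)c(NC(=O)C(C)(C)CCCCCOc2ccccc2)c2c1CC(C)(C)O2`, has not been measured. It differs from compound 3 in one place: phenoxy in place of benzyl on a saturated chain carbon, six bonds along the chain from a carbonyl carbon. Within the data shown here, the only measured step at the chain end is a 2.5-fold higher number from compound 2 to compound 3 (0.39 log units; beyond the scatter), which swapped the terminal group outright; no measured pair exchanges a chain carbon for an oxygen at this position, so nothing speaks directly to the change. The terminal ring is kept, the heavy-atom count is unchanged, and one acceptor enters. On that basis the expected step in this assay is none beyond the scatter, a 1.2-fold higher number from compound 3 to compound 4 (0.09 log units; within the scatter). Compound 4 is estimated at 100 nM, with a range from 40 nM to 250 nM.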

Compound 4, half-maximal inhibitory concentration: 86 nM
For compound 4 the middle estimate is 1.2-fold (0.07 log units) above the measured one, and the stated range covers the measured number.
By their numbers in this assay, from the lowest: compound 2; then compounds 3 and 4 (each within the scatter of the next); then compound 1.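

Working notes: compound 3 and compound 4 form the first pair in the series that keeps the terminal ring and exchanges only a chain carbon for an oxygen, six bonds along the chain from a carbonyl carbon, and this assay gives a 1.1-fold higher number from compound 3 to compound 4 (0.03 log units; within the scatter), so phenoxy in place of benzyl leaves no readable difference at this place. The earlier chain-end step swapped the terminal group outright, and the new comparison with the alkyl-ended compound, a 2.6-fold higher number from compound 2 to compound 4 (0.42 log units; beyond the scatter), is modest and beyond the scatter, in the same direction as a 2.5-fold higher number from compound 2 to compound 3 (0.39 log units; beyond the scatter), so both phenyl-ended chains give higher numbers than compound 2. No accompanying measurement accounts for these results.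

Open, from the compounds shown here alone, is whether an amine or a thioether link at the same place would also read within the scatter of compound 3. Also open, going by these compounds, are the effects of a carboxylic acid on the terminal ring and of a longer chain between the carbonyl and the phenoxy group.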